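Shortening the sulfonyl chain and capping the sulfonamide nitrogen

The source may report more compounds than this note shows. Statements on the series, on what has been measured and on what is new or still open speak of the compounds shown alone.

Measured so far:
Compound 1 `CC(=O)N1CCC[C@H](NS(=O)(=O)C(C)C)[C@@H]1CO[C@H]1CC[C@@H](C(C)C)CC1`: 940 nM
Compound 2 `CCCS(=O)(=O)N[C@H]1CCCN(C(C)=O)[C@H]1CO[C@H]1CC[C@@H](C(C)C)CC1`: 2500 nM

Within the data shown here, in a functional assay on CHO-K1 cells for agonist activity at Orexin receptor type 2 (Homo sapiens), read by FLIPR and calcium flux (on this read-out higher numbers stand for an effect only at larger amounts of compound and lower numbers for an effect already at smaller amounts), compound 2 gives 2500 nM, the highest of the two numbers known; the nearest is compound 1 with 940 nM. Among the measured compounds shown here, the only measured step, a 2.7-fold higher number from compound 1 to compound 2 (0.42 log units; beyond the scatter), concerns the alkyl group on the sulfonyl sulfur.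

Compound 3 `CC(=O)N1CCC[C@H](N(C)S(C)(=O)=O)[C@@H]1CO[C@H]1CC[C@@H](C(C)C)CC1` carries methyl(methylsulfonyl)amino in place of (propylsulfonyl)amino on a saturated ring carbon. Two things change at once: the chain on the sulfonyl sulfur shrinks from propyl to methyl, and the hydrogen-bond donor on the sulfonamide nitrogen is replaced by a methyl group. For the measured compounds named here, the step of a 2.7-fold higher number from compound 1 to compound 2 (0.42 log units; beyond the scatter) shows that the size of this chain matters by a modest amount, but no measured pair speaks to removing the donor. A step of about a 1.1-fold lower number from compound 2 to compound 3 (0.06 log units; within the scatter) is therefore expected, with wide uncertainty. For compound 3 the expected value is 2200 nM, within 600 nM to 9000 nM.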

Compound 3, half-maximal effective concentration: > 30000 nM
Compound 3: no number, only a limit; the forecaster's own chance of this, stated with the estimate: 10%; middle value at least 13-fold (1.13 log units) from the limit.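

In this assay compound 3 gives no number, only a limit: the limit of > 30000 nM in this assay, at which 1 of the 3 values shown sits.

Even so, replacing the sulfonamide at this saturated ring carbon with methyl(methylsulfonyl)amino gives an at least 12-fold higher number from compound 2 to compound 3 (1.07 log units; beyond the scatter), and measured against the isopropyl analogue it gives an at least 31-fold higher number from compound 1 to compound 3 (1.50 log units; beyond the scatter). Both steps are large, whereas the change of chain alone gave only the modest 2.7-fold higher number from compound 1 to compound 2 (0.42 log units; beyond the scatter), so this position responds far more strongly to the combined change than to swapping isopropyl for propyl.

Which part of that change carries the step stays open, the shorter chain on the sulfonyl sulfur or the methyl that replaces the hydrogen-bond donor on the nitrogen. A methylsulfonylamino group that keeps its nitrogen hydrogen, or a propylsulfonyl group with a methyl on that nitrogen, would separate the two.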